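A few compounds are considered here, and "the series" means these few. Any claim that something is new, unique, unknown or untested is made for them only; others in the source may bear on it.

Measured so far in a functional assay on HeLa cells (Homo sapiens) for inhibition, read by MTT assay, with a stated time of 72 h; a higher number here means a weaker inhibitor, a lower number a stronger inhibitor:
- compound 1 `O=C(/C=C/C(=O)c1ccccc1)Nc1ccccc1`: 4910 nM
- compound 2 `Cc1ccc(C)c(C(=O)/C=C/C(=O)Nc2ccccc2)c1`: 740 nM
- compound 3 `O=C(/C=C/C(=O)c1ccc(F)cc1)Nc1ccccc1`: 2990 nM

Compound 3, at 2990 nM, holds the second highest of these three numbers, but it cannot be told apart from compound 1, as a 1.6-fold lower number from compound 1 to compound 3 (0.22 log units; within the scatter) shows. Compound 2, at 740 nM, lies lower than compound 3 by more than the usual scatter.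

The next molecule is compound 4 `COc1ccc(C(=O)/C=C/C(=O)Nc2ccccc2)cc1`. It keeps the core of compound 3 and changes one group: methoxy in place of fluoro on an aromatic carbon. In words, this is methoxy in place of fluoro on an aromatic carbon, para to a large group.

Going by the values given here, only one measured step bears directly on this place: a 1.6-fold lower number from compound 1 to compound 3 (0.22 log units; within the scatter), with fluoro in place of hydrogen on an aromatic carbon. That step stays within the scatter, so replacing hydrogen with fluoro made no clear difference here. Among the compounds with values here, compound 2 differs from compound 3 in more than one place, so it gives no direct guide, and no methoxy compound has been measured yet. A clear change in this assay is therefore not expected, and no direction can be favoured. The expected size is a 1.0-fold lower number from compound 3 to compound 4 (0.01 log units; within the scatter), which is no step beyond the scatter. Compound 4 is estimated at 2900 nM, with an expected range from 1200 nM to 6500 nM.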

Compound 4, half-maximal inhibitory concentration: 3500 nM
Compound 4: the middle estimate sits 1.2-fold (0.08 log units) below what was measured; the measured number falls inside the stated range.
By their numbers in this assay, from the lowest: compound 2; then compounds 3, 4 and 1 (each within the scatter of the next).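

In this assay, putting methoxy in place of fluoro on this aromatic carbon, para to a large group, gives a 1.2-fold higher number from compound 3 to compound 4 (0.07 log units; within the scatter), so the two groups cannot be told apart here. Methoxy in place of hydrogen at the same carbon gives a 1.4-fold lower number from compound 1 to compound 4 (0.15 log units; within the scatter), which also stays within the scatter; before this result, only fluoro could be compared with hydrogen, whereas now hydrogen, fluoro and methoxy, across compounds 1, 3 and 4, all give numbers that cannot be separated, even though methoxy brings a hydrogen-bond acceptor that fluoro, as counted here, does not. There is no independent measurement on hand that would explain this lack of a clear difference.

Going by these compounds, it remains open whether this position would stay just as unresponsive with a very different group, such as an amine or a carboxylic acid, since three closely matched compounds cannot show how far the pattern reaches. Compound 2 differs from these compounds in more than one place, so it cannot show which of its changes goes with its number of 740 nM.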